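The compounds below may be only part of what the source reports. "The series", "measured", "known", "first", "only" and "open" are said of these compounds alone.

Among the measured compounds shown here, in an ADME assay on HeLa cells (Homo sapiens) for cytotoxicity, read by sulforhodamine B assay, with a stated time of 48 h, tested at 10 uM (on this read-out lower numbers stand for less inhibition and higher numbers for more inhibition at the one concentration tested (going by the name of the read-out)), compound 1 `COc1nc2ccc(Br)cc2cc1C(c1ccccc1)n1cc(-c2ccccc2F)nn1` gives 14.1%, the higher of the two numbers measured so far. Compound 2 `COc1nc2ccc(Br)cc2cc1C(c1ccccc1)n1cc(-c2ccc(OC(F)(F)F)cc2)nn1` stands nearest to it; in this assay compound 2 gives -2.24%. For the measured compounds named here, the single measured step is a number 16.3 percentage points lower from compound 1 to compound 2 (beyond the scatter), and it shows that exchanging the group at this position can move the read-out by a modest amount while both numbers remain in the low part of the scale.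

Compound 3 `CCCCCCc1cn(C(c2ccccc2)c2cc3cc(Br)ccc3nc2OC)nn1` has not yet been measured. It differs from compound 1 in one place: hexyl in place of 2-fluorophenyl on an aromatic carbon. Going by the values given here, no measured pair shows a chain in place of an aromatic ring at this position, so the step from compound 1 to compound 2 bears on it only as a guide to how much a change at this site has moved the number. A small change is therefore expected, possibly downward and probably within the scatter, namely a number 5.1 percentage points lower from compound 1 to compound 3 (within the scatter). Compound 3 is estimated at 9%, with a range from -6% to 24%.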

Compound 3, a percentage reported as inhibition, at one concentration (the size of the read-out at that concentration, not a potency): -0.97%
The estimate for compound 3 lay 10 percentage points above the measured number; the measured number falls inside the stated range.
By their numbers in this assay, from the lowest: compounds 2 and 3 (each within the scatter of the next); then compound 1.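

In this assay, the change from an aromatic ring to a chain at this position gives a number 15.1 percentage points lower from compound 1 to compound 3 (beyond the scatter), so a group with no ring also ends up well under the number of the 2-fluorophenyl compound. Hexyl and 4-(trifluoromethoxy)phenyl cannot be told apart here, with a number 1.3 percentage points higher from compound 2 to compound 3 (within the scatter), so keeping an aromatic ring on the triazole-bearing carbon does not by itself hold the number up, and among these three groups only 2-fluorophenyl stands clear of the others. Nothing available explains why these two quite different groups land so close together, and the size of the gap to 2-fluorophenyl stays a bare observation.

The compounds shown leave open whether the fluorine itself or its place on the ring sets 2-fluorophenyl apart, which unsubstituted phenyl or 4-fluorophenyl would help to settle. They also leave open how the number responds to a shorter chain such as butyl, or to a chain ending in an amine or a carboxylic acid, and whether any group here could lift the read-out beyond the low part of the scale.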